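The source may report more compounds than this note shows. Statements on the series, on what has been measured and on what is new or still open speak of the compounds shown alone.

Measured compounds:
compound 1 `Cc1cccc(/N=C2/NC(=O)/C(=C/c3ccccn3)S2)c1` — 39.7%
compound 2 `O=C1N/C(=N/c2ccc(F)cc2)S/C1=C\c1ccccn1` — 34.7%

In a functional assay on the whole organism (strain Wistar) for inhibition, with Rattus norvegicus as the target, read by paw edema, with stated times of 30 min and 120 min, at a dose of 10 mg/kg by the oral route (on this read-out lower numbers stand for less inhibition and higher numbers for more inhibition at the one dose given (going by the name of the read-out)), compound 1 gives 39.7% and compound 2 gives 34.7%. Compound 2 thus has the lowest of the two numbers, but its nearest neighbour, compound 1, is only a number 5 percentage points lower from compound 1 to compound 2 (within the scatter) away, so the two values cannot be told apart. Compound 3 `O=C1N/C(=N/c2ccccc2Cl)S/C1=C\c1ccccn1` has not been measured in this assay. It differs from compound 2 in one place: 2-chlorophenyl in place of 4-fluorophenyl on a double-bonded nitrogen. Among the compounds with values here, the one measured step, a number 5 percentage points lower from compound 1 to compound 2 (within the scatter), also exchanged the aryl group on the double-bonded nitrogen and stayed within the scatter, so there is no sign that this position moves the read-out much. On that basis the step from compound 2 to compound 3 is expected to be a number 1.3 percentage points higher from compound 2 to compound 3 (within the scatter), with no change beyond the scatter. Compound 3 is therefore estimated at 36%, in a range from 22% to 50%.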

Compound 3, a percentage reported as inhibition, in the whole organism at one dose (the size of the read-out at that dose, not a potency): 26.2%
For compound 3 the middle estimate is 9.8 percentage points above the measured one; the measured number falls inside the stated range.
By their numbers in this assay, from the lowest: compounds 3, 2 and 1 (each within the scatter of the next, the first and the last beyond it).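

In this assay, putting 2-chlorophenyl in place of 4-fluorophenyl on the double-bonded nitrogen gives a number 8.5 percentage points lower from compound 2 to compound 3 (within the scatter), so this exchange alone cannot be told from the scatter. Within the data shown here, putting 2-chlorophenyl in place of 3-methylphenyl at the same place gives a number 13.5 percentage points lower from compound 1 to compound 3 (beyond the scatter), the first step here to pass beyond the scatter, which shows that the choice of aryl group can shift the read-out, if only modestly. Nothing available explains this difference between the aryl groups.

The compounds shown carry only methyl-, fluoro- or chloro-substituted phenyl groups on this nitrogen, so it stays open how a methoxy group, an amine or a carboxylic acid on the phenyl ring would behave. On these data alone, it also stays open whether the same order would hold at other doses.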